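One fluoro added to compound 3

A few compounds are considered here, and "the series" means these few. Any claim that something is new, unique, unknown or untested is made for them only; others in the source may bear on it.

In an ADME assay on liver (Homo sapiens) for metabolic stability, read by LC-MS, using microsomes and NADPH (a higher number here means that more of the compound is left, a lower number that less of the compound is left), compound 3 `COc1cc(CN(CC(C)C)C(CC(=O)O)c2ccc(Cl)cc2)ccc1OCCN1C(=O)CCC1=O` gives 80%. That lies within the usual scatter of compound 2 `CCCN(Cc1ccc(OCCn2c(=O)ccn(C)c2=O)c(OC)c1)C(CC(=O)O)c1ccc2c(c1)CCO2`, which gives 83%. It lies well beyond the scatter from compound 1 `CCCCN(Cc1ccc(OCCn2c(=O)ccn(C)c2=O)c(OC)c1)C(CC(=O)O)c1ccc(Cl)cc1`, which gives 38%. These three compounds differ from one another in more than one place, so none of the gaps can be tied to a single change. Compound 1 and compound 3 both carry the 4-chlorophenyl group, yet their values still lie far apart.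

Compound 4 `COc1cc(CN(CC(C)C)C(CC(=O)O)c2ccc(Cl)c(F)c2)ccc1OCCN1C(=O)CCC1=O` alters compound 3 in one place only: fluoro in place of hydrogen on an aromatic carbon, ortho to a chloro group and meta to a large group (fluoro in place of hydrogen on an aromatic carbon). This turns 4-chlorophenyl to 4-chloro-3-fluorophenyl. Within the data shown here, with no measured one-place step as a guide, no step beyond the scatter is expected in this assay, and neither direction is favoured. The expected step, no change at the digits printed from compound 3 to compound 4 (within the scatter), stays within the scatter. For compound 4 the estimated value is 80%, with an expected range from 62% to 92%.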

Compound 4, percent of the compound remaining: 76%
The estimate for compound 4 lay 4 percentage points above the measured number; low and high end bracket the measured number.
By their numbers in this assay, from the lowest: compound 1; then compounds 4, 3 and 2 (each within the scatter of the next).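

In this assay, among these compounds, turning 4-chlorophenyl to 4-chloro-3-fluorophenyl gives a number 4 percentage points lower from compound 3 to compound 4 (within the scatter), the first step in this set that can be tied to a single place. Among the compounds shown here, for this one pair of compounds, then, a fluoro on this aromatic carbon, ortho to a chloro group, does not move the number beyond the usual scatter, something the earlier compounds could not show since they differ in more than one place. No measurement at hand bears on the reason for this result.

Still open, from the compounds shown here alone, is whether a larger group at this same position, such as trifluoromethyl or methoxy, would leave the number within the scatter too. Also open, going by these compounds, is how the same fluoro would read on compound 1, which gives 38%, where much less of the compound is left.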